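Predicting Compound 4: Difluorophenyl Replacing Methoxyphenyl

This account rests on a few compounds, and the source may have more. Where it says the series, first, only, none or still open, it means among the compounds named here.

Measured so far in a functional assay on RPMI-8226 cells (Homo sapiens) for cytotoxicity, read by sulforhodamine B assay, with a stated time of 48 h, tested at 100 uM; a lower number here means a stronger effect, a higher number a weaker effect of the compound at the concentration tested:
compound 1 `COc1ccc(-c2cc(/C=C/C(=O)c3ccc(OC)c(OC)c3)[nH]n2)cc1` gives -62%
compound 2 `COc1ccc(-c2cc(/C=C/C(=O)c3ccc(N)cc3)[nH]n2)cc1OC` gives -40%
compound 3 `COc1ccc(C(=O)/C=C/c2cc(-c3cc(OC)c(OC)c(OC)c3)n[nH]2)cc1` gives -34%

Among these three numbers, compound 3 stands highest. Compound 2 sits within the usual scatter of compound 3, so the two cannot be told apart. Compound 1 lies well beyond that scatter, with a clearly lower number and so a stronger effect than compound 3.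

Compound 4 `COc1cc(-c2cc(/C=C/C(=O)c3ccc(F)c(F)c3)[nH]n2)cc(OC)c1OC` has not yet been measured. It differs from compound 3 in one place: 3,4-difluorophenyl in place of 4-methoxyphenyl on a carbonyl carbon. Among the measured compounds shown here, no measured pair shows this kind of exchange, so its size cannot be read from the data. In this assay the step expected here is a number 1 percentage points lower from compound 3 to compound 4 (within the scatter), with no change beyond the scatter in either direction. Compound 4 is therefore estimated at -35%, within a range from -60% to -5%.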

Compound 4, a percentage reported as activity, at one concentration (the size of the read-out at that concentration, not a potency): -36%
For compound 4 the middle estimate is 1 percentage points above the measured one, within the range that was stated.
By their numbers in this assay, from the lowest: compound 1; then compounds 2, 4 and 3 (each within the scatter of the next).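

In this assay there is a number 2 percentage points lower from compound 3 to compound 4 (within the scatter) when 3,4-difluorophenyl replaces 4-methoxyphenyl on a carbonyl carbon. At this place, then, a ring with two fluorines and a ring with one methoxy group cannot be told apart, although the exchange removes a hydrogen-bond acceptor. Nothing available explains this result.

This single exchange leaves open how other groups on the same carbonyl carbon would read, such as a ring carrying a carboxylic acid or an amine. It also cannot show whether the same exchange would read alike on a different core.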